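From methyl to trifluoromethyl: working notes

The source may hold more compounds than are shown below. What is called first, only, known or untested is meant among the compounds shown, and "the series" means these compounds.

Among the compounds with values here, in a functional assay on HCT-116 cells (Homo sapiens) for antiproliferative activity, read by CellTiter-Glo, with a stated time of 72 h (on this read-out lower numbers stand for stronger inhibition and higher numbers for weaker inhibition), compound 2 `Cc1ccc(-c2cc(/C=C/c3ccc(C(=O)NO)cc3)ccn2)cc1` gives 2390 nM, the only number so far. Compound 1 `O=C(NO)c1ccc(/C=C/c2ccnc(-c3ccc(F)cc3)c2)cc1` gives > 10000 nM, which is a limit of the assay. Compound 3 `O=C(NO)c1ccc(/C=C/c2ccnc(-c3ccc(C(F)(F)F)cc3)c2)cc1` carries trifluoromethyl in place of methyl on an aromatic carbon, para to a large group: trifluoromethyl in place of methyl on an aromatic carbon. Within the data shown here, the one measured step that bears on this change, an at least 4.1-fold lower number from compound 1 to compound 2 (0.62 log units; beyond the scatter), is methyl in place of fluoro on an aromatic carbon. On that single step, a modest move to a higher number is expected in this assay, the expected step being a 2.1-fold higher number from compound 2 to compound 3 (0.32 log units; beyond the scatter). For compound 3 the estimate is 5000 nM, with an expected range of 1800 nM to 14000 nM.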

Compound 3, half-maximal inhibitory concentration: > 10000 nM
Compound 3 gave a limit, no number (the forecaster's own chance of this, stated with the estimate: 35%); middle value at least 2.0-fold (0.30 log units) away from the limit.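

In this assay, trifluoromethyl in place of methyl on this aromatic carbon gives an at least 4.1-fold higher number from compound 2 to compound 3 (0.62 log units; beyond the scatter), and the value of compound 3 is a limit of the assay, not a number. Of the three groups shown at this position, only methyl gives a number, so the drop is not confined to fluoro. The remaining step, between compound 1 and compound 3, cannot be read because both values are limits: the limit of > 10000 nM in this assay, at which 2 of the 3 values shown sit.

Still open, from the compounds shown here alone, is whether an ethyl, a methoxy or an amine at this position would give a number, and how far compound 1 and compound 3 lie beyond the limit.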